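Trading a Branched Chain for a Ring

This account rests on a few compounds, and the source may have more. Where it says the series, first, only, none or still open, it means among the compounds named here.

Among the compounds with values here, compound 1 `CCCC(C)Oc1cccc2ccc(N)nc12` is one of three compounds measured in an assay on cells with melanin-concentrating hormone receptor 1 (Homo sapiens) as the target, read by radioligand binding; a lower number here means a stronger inhibitor, a higher number a weaker inhibitor. In this assay compound 1 gives 105 nM, the lowest of the three numbers. Compound 2 `Nc1ccc2cccc(OCC3CC4CCC3C4)c2n1` gives 137 nM, which lies within the scatter of compound 1, so the two cannot be told apart. Compound 3 `CCCOc1cccc2ccc(N)nc12` gives 1100 nM; the step of a 10-fold higher number from compound 1 to compound 3 (1.02 log units; beyond the scatter) is large and clearly beyond the scatter.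

Compound 4 `Nc1ccc2cccc(OC3CCCCC3)c2n1` has not yet been measured in this assay. It differs from compound 1 in one place:
cyclohexyl in place of 1-methylbutyl on an oxygen on an aromatic ring
Within the data shown here, only one measured step changes the group on this oxygen, namely a 10-fold higher number from compound 1 to compound 3 (1.02 log units; beyond the scatter), and it shows that shortening the group to propyl costs a great deal. Compound 4 keeps a bulky group there, and compound 2, which also carries a ring on that oxygen, sits within the scatter of compound 1. Among the measured compounds shown here, no measured step therefore points to a change beyond the scatter. The step of a 1.0-fold higher number from compound 1 to compound 4 (0.02 log units; within the scatter) is the one expected here. Compound 4 is estimated to give about 110 nM, with a likely range from 40 nM to 320 nM.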

Compound 4, half-maximal inhibitory concentration: 361 nM
The estimate for compound 4 lay 3.3-fold (0.52 log units) below the measured number; the measured number lies above the stated range.
By their numbers in this assay, from the lowest: compounds 1 and 2 (each within the scatter of the next); then compound 4; then compound 3.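

In this assay, replacing 1-methylbutyl with cyclohexyl on this oxygen raises the number by a modest but real amount (a 3.4-fold higher number from compound 1 to compound 4 (0.54 log units; beyond the scatter)), so the open branched chain and this six-membered ring are not interchangeable here. Cyclohexyl still gives a lower number than propyl (a 3.0-fold lower number from compound 3 to compound 4 (0.48 log units; beyond the scatter)), which places compound 4 between compound 1 and compound 3 and shows that the position tolerates a ring better than the short straight chain. Although cyclohexyl holds more heavy atoms than 1-methylbutyl, compound 4 has the higher number, so compound 4 goes against any simple rule that a larger group on this oxygen gives a lower number, even though compound 3 alone might suggest one.

No measurement at hand explains why the ring and the branched chain differ. The compounds shown leave open how a smaller cyclopentyl ring, a tetrahydropyranyl ring with an oxygen in it, or a longer branched chain would compare on this oxygen, and so whether the open chain or the particular ring size matters more.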